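Aryl urea series: iodo for isopropyl on compound 2

A few compounds are considered here, and "the series" means these few. Any claim that something is new, unique, unknown or untested is made for them only; others in the source may bear on it.

Compound 2 `CC(C)c1ccc(NC(=O)N[C@@H](C)c2ccccc2)cc1` gives 96% in an ADME assay on the whole organism with Oryza sativa as the target, tested at 1 uM (a higher number here means a weaker effect of the compound at the concentration tested, a lower number a stronger effect), the top of the three numbers shown. Compound 3 `C[C@@H](NC(=O)Nc1ccccc1C(F)(F)F)c1ccccc1` gives 95% in this assay, within the scatter of compound 2. Within the data shown here, compound 1 `CC(C)c1ccc(NC(=O)N[C@H](C)c2ccccc2)cc1` gives 79% in this assay; the only measured step, a number 17 percentage points higher from compound 1 to compound 2 (beyond the scatter), rests on the fact that compounds 1 and 2 differ only in the configuration as drawn alone. Compound 4 `C[C@H](NC(=O)Nc1ccc(I)cc1)c1ccccc1` differs from compound 2 by iodo in place of isopropyl on an aromatic carbon. Among the measured compounds shown here, no measured step alters a group on the aromatic ring, so the configuration step does not bear on this change; compounds 2 and 3 carry different groups there and show close numbers. For compound 4 a step of a number 6 percentage points lower from compound 2 to compound 4 (within the scatter) is expected, within the scatter. Compound 4 is therefore estimated at 90%, between 70% and 100%.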

Compound 4, a percentage reported as activity, at one concentration (the size of the read-out at that concentration, not a potency): 97%
Compound 4: middle estimate off by 7 percentage points, on the low side, within the range that was stated.
By their numbers in this assay, from the lowest: compound 1; then compounds 3, 2 and 4 (each within the scatter of the next).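

In this assay, iodo in place of isopropyl on an aromatic carbon para to a large group gives a number 1 percentage points higher from compound 2 to compound 4 (within the scatter) and so no readable change at this position. Among these compounds, this is the first measured step at the aromatic ring, and it shows that replacing these three carbons with one iodine leaves both compounds at the weak-effect end of the numbers. The evidence at hand does not bear on this change.

On these data alone, whether iodo gives the same result on the configuration of compound 1 remains open. Also open, as far as these compounds go, is what an amine or a carboxylic acid would give at this position.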